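The source may hold more compounds than are shown below. What is called first, only, known or untested is meant among the compounds shown, and "the series" means these compounds.

Compound 3, whose structure is `COc1cc(Nc2nc(SCc3ccc(C(F)(F)F)cc3)nc3ccccc23)cc(OC)c1`, stands alone among the three measured compounds in giving an actual number in a functional assay on MCF7 cells (Homo sapiens) for cytotoxicity, read by MTT assay, with a stated time of 72 h; a higher number here means a weaker inhibitor, a lower number a stronger inhibitor. In this assay compound 3 gives 6990 nM. Compound 1, with structure `CCOc1ccccc1Nc1nc(SCc2ccc(C(F)(F)F)cc2)nc2ccccc12`, reaches only a limit of the assay, > 50000 nM. Compound 2, with structure `CCOc1ccc(Nc2nc(SCc3ccc(C(F)(F)F)cc3)nc3ccccc23)cc1`, likewise reaches only a limit, > 50000 nM. The steps from these two to compound 3 are therefore readable only in part: an at least 7.1-fold lower number from compound 1 to compound 3 (0.85 log units; beyond the scatter) and an at least 7.1-fold lower number from compound 2 to compound 3 (0.85 log units; beyond the scatter), both bounded by the limit of > 50000 nM in this assay, at which 2 of the 3 values shown sit. The step between compound 1 and compound 2 cannot be sized for the same reason: a step that the two limits leave unreadable from compound 1 to compound 2.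

Compound 4, whose structure is `Fc1ccc(Nc2nc(SCc3ccc(C(F)(F)F)cc3)nc3ccccc23)cc1Cl`, differs from compound 3 in one place: 3-chloro-4-fluorophenyl in place of 3,5-dimethoxyphenyl on a nitrogen on an aromatic ring. Among the measured compounds shown here, no measured step replaces the 3,5-dimethoxyphenyl group with a halogenated ring, so the only bearing comes from the two steps into compound 3, each of which shows that changing the group on this nitrogen away from 3,5-dimethoxyphenyl can lose a modest amount of potency or more. A weaker result for compound 4 is therefore expected, with wide uncertainty. The expected step for compound 4 is estimated as a 2.9-fold higher number from compound 3 to compound 4 (0.46 log units; beyond the scatter). Compound 4 is estimated at 20000 nM, expected to fall between 5000 nM and 60000 nM.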

Compound 4, half-maximal inhibitory concentration: 23000 nM
Estimate against measurement, compound 4: 1.2-fold (0.06 log units) below; measured number inside the range.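

Among the compounds shown here, the change to 3-chloro-4-fluorophenyl gives a 3.3-fold higher number from compound 3 to compound 4 (0.52 log units; beyond the scatter) in this assay, the first step on this nitrogen with a real number at both ends. The same group also gives an at least 2.1-fold lower number from compound 2 to compound 4 (0.33 log units; beyond the scatter) when it replaces 4-ethoxyphenyl, and an at least 2.1-fold lower number from compound 1 to compound 4 (0.33 log units; beyond the scatter) when it replaces 2-ethoxyphenyl, so this position can give a measurable number with a ring that carries halogens and no oxygen. Oxygen on this ring therefore does not order the four compounds by itself: the 3,5-dimethoxyphenyl of compound 3 gives the lowest number, while the ethoxyphenyl groups of compound 1 and compound 2 give the highest, and the halogenated ring of compound 4 lies in the middle.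

On these data alone, how far compound 1 and compound 2 really lie from compound 4 stays open, and the step between those two cannot be read: the limit of > 50000 nM in this assay, at which 2 of the 4 values shown sit. It also remains open how this position would respond to a single methoxy group, to an amine or a carboxylic acid on the ring, or to a longer chain in place of the ethoxy group.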